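Rat liver microsome stability: cyclopropyl replacing trifluoromethylphenyl

A few compounds are considered here, and "the series" means these few. Any claim that something is new, unique, unknown or untested is made for them only; others in the source may bear on it.

Measured so far:
- compound 1, `CC#C[C@@H](Cc1nnn[nH]1)c1ccc(OCc2ccc3scc(-c4ccccc4C(F)(F)F)c3c2)cc1`: 0.167 h
- compound 2, `CC#C[C@@H](Cc1nnn[nH]1)c1ccc(OCc2ccc3scc(-c4ccc(OCCC(C)(C)O)cc4C)c3c2)cc1`: 1.03 h
- compound 3, `CC#C[C@@H](Cc1nnn[nH]1)c1ccc(OCc2ccc3scc(-c4ccc(OCCCS(C)(=O)=O)cc4C)c3c2)cc1`: 1.48 h

In an ADME assay on microsomes from liver (Rattus norvegicus) for metabolic stability (a higher number here means that the compound lasts longer, a lower number that the compound disappears faster), compound 1 stands lowest of the three, with compound 2 the nearest of the other two and compound 3 the furthest; both of those gaps are beyond the usual scatter. Between compound 2 and compound 3 the only measured single-point step is a 1.4-fold higher number from compound 2 to compound 3 (0.16 log units; within the scatter), which concerns a chain attached through an oxygen on an aromatic ring and does not touch the group that changes here.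

Compound 4, `CC#C[C@@H](Cc1nnn[nH]1)c1ccc(OCc2ccc3scc(C4CC4)c3c2)cc1`, differs from compound 1 by cyclopropyl in place of 2-(trifluoromethyl)phenyl on an aromatic carbon. Going by the values given here, no measured step in this assay involves the group on that aromatic carbon of the fused system, so nothing bears directly on the size or direction of the change. Among the compounds with values here, the only guide is that compound 1, the sole compound carrying 2-(trifluoromethyl)phenyl, is the lowest of the set, which leaves room in either direction but gives no pattern to lean on.

Compound 4 is therefore expected near 0.3 h, in a wide range from 0.1 h to 1 h. This corresponds to an expected 1.8-fold higher number from compound 1 to compound 4 (0.25 log units; within the scatter), a step of uncertain direction.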

Compound 4, half-life: 1.72 h
The estimate for compound 4 lay 5.7-fold (0.76 log units) below the measured number; measured number outside the range, above it.
By their numbers in this assay, from the lowest: compound 1; then compounds 2, 3 and 4 (each within the scatter of the next).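

At the aromatic carbon two ring bonds from the ring sulfur, the group has a large effect on the half-life in this assay (a 10-fold higher number from compound 1 to compound 4 (1.01 log units; beyond the scatter)). Going by these compounds alone, the earlier step concerned only a chain attached through an oxygen on an aromatic ring, so this is the first measured step at this position, and it lies beyond the scatter; 2-(trifluoromethyl)phenyl, with its 10 heavy atoms, gives way to cyclopropyl, with 3, and the six-membered aromatic ring goes with it. No measurement shown explains the size of this step.

This single exchange does not separate the loss of the trifluoromethyl group from the loss of the aromatic ring or from the drop in heavy atoms, and a plain phenyl, a methyl or a cyclobutyl on the same aromatic carbon would help to tell these apart. Also open, from the compounds shown here alone, is how cyclopropyl at this position behaves when combined with a chain on an oxygen, such as the methylsulfonyl-bearing chain of compound 3, or with a carboxylic acid in place of the tetrazole-bearing side of the shared core.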